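Swapping the Aryl on the Triazole: Compound 4 Estimated

The source may report more compounds than this note shows. Statements on the series, on what has been measured and on what is new or still open speak of the compounds shown alone.

Among the measured compounds shown here, compound 3 `CCc1ccccc1-n1nncc1CN1C(=O)C2(C(C#N)=C(N)Oc3c(N)cc4nc5ccccc5nc4c32)c2ccccc21` is the only compound of the three for which a functional assay on MCF7 cells (Homo sapiens) for antiproliferative activity, read by MTT assay, with a stated time of 48 h (on this read-out lower numbers stand for stronger inhibition and higher numbers for weaker inhibition), returns a number: compound 3 gives 24600 nM. Compound 1 `N#CC1=C(N)Oc2c(c3nc4ccccc4nc3c3ccccc23)C12C(=O)N(Cc1cnnn1-c1ccc(F)cc1)c1ccccc12` gives > 50000 nM, which is a limit of this assay rather than a number. Compound 2 `N#CC1=C(N)Oc2c(c3nc4ccccc4nc3c3ccccc23)C12C(=O)N(Cc1cnnn1-c1ccc([N+](=O)[O-])cc1)c1ccccc12` likewise gives > 50000 nM, again a limit. Two of the three values shown therefore sit at the limit of > 50000 nM in this assay, at which 2 of the 3 values shown sit. For the measured compounds named here, the one step between measured compounds, a step that the two limits leave unreadable from compound 1 to compound 2, has both of its ends at a limit and so cannot be read in size. Compound 4 `COc1ccc(-n2nncc2CN2C(=O)C3(C(C#N)=C(N)Oc4c(N)cc5nc6ccccc6nc5c43)c3ccccc32)cc1` differs from compound 3 by a single change: 4-methoxyphenyl in place of 2-ethylphenyl on an aromatic nitrogen. Going by the values given here, no measured step covers this kind of exchange, so nothing in these data points to a move in either direction, and the expectation is a step no larger than the usual scatter. The step from compound 3 to compound 4 is expected to be a 1.0-fold higher number from compound 3 to compound 4 (0.01 log units; within the scatter). Compound 4 is accordingly estimated at 25000 nM, within a range from 8000 nM to 80000 nM, with a real chance that this assay again reports only a limit.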

Compound 4, half-maximal inhibitory concentration: > 50000 nM
Compound 4 gave a limit, no number; the forecaster's own chance of this, stated with the estimate: 40%; middle value at least 2.0-fold (0.30 log units) away from the limit.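

In this assay, among the compounds shown here, replacing 2-ethylphenyl with 4-methoxyphenyl on the aromatic nitrogen gives an at least 2.0-fold higher number from compound 3 to compound 4 (0.30 log units; that floor lies within the scatter), the first readable step at this position, although its floor alone does not separate the two compounds from ordinary repeat scatter. Compound 4 gives > 50000 nM, which is a limit of the assay and not a number, so the real size of the step could be larger than this floor. The step from compound 1 to compound 2 cannot be read, and compound 3 remains the only compound here with a number: the limit of > 50000 nM in this assay, at which 3 of the 4 values shown sit.

Going by these compounds, whether a plain phenyl, or a phenyl carrying an amine or a carboxylic acid, on this ring nitrogen would return a number in this assay stays open. Also open, on these data alone, is whether the departure of 2-ethylphenyl or the arrival of 4-methoxyphenyl counts for more.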